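A Chloro Exchange in a Narrow Set of Values

The source may report more compounds than this note shows. Statements on the series, on what has been measured and on what is new or still open speak of the compounds shown alone.

In a functional assay on HEY cells (Homo sapiens) for cytotoxicity, read by MTT assay, with a stated time of 72 h (on this read-out higher numbers stand for weaker inhibition and lower numbers for stronger inhibition), compound 1 `COc1ccc(CNC(=O)c2nc(Br)c3cccnc3c2N[C@H]2CC[C@H](N)CC2)cc1` gives 4000 nM while compound 2 `N[C@H]1CC[C@H](Nc2c(C(=O)NCc3ccc(Cl)cc3Cl)nc(Br)c3cccnc23)CC1` gives 5000 nM and compound 3 `CN(C)c1ccc(CNC(=O)c2nc(Br)c3cccnc3c2N[C@H]2CC[C@H](N)CC2)cc1` gives 5300 nM on the same read-out. Compound 3 thus lies within the scatter of both other compounds, and no order among the three can be read. Compound 4 `N[C@H]1CC[C@H](Nc2c(C(=O)NCc3ccc(Cl)cc3)nc(Br)c3cccnc23)CC1` has not yet been measured. It differs from compound 3 by chloro in place of dimethylamino on an aromatic carbon, a change counted as chloro in place of dimethylamino on an aromatic carbon and placed para to a large group.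

The closest evidence is the exchange of 2,4-dichlorophenyl for 4-(dimethylamino)phenyl, which gave a 1.1-fold higher number from compound 2 to compound 3 (0.03 log units; within the scatter) as its result. Dimethylamino in place of methoxy gave a 1.3-fold higher number from compound 1 to compound 3 (0.12 log units; within the scatter) in turn, and 2,4-dichlorophenyl in place of 4-methoxyphenyl gave a 1.3-fold higher number from compound 1 to compound 2 (0.10 log units; within the scatter) as well. All three steps stay within the scatter, although the set is small and none of them is the exact exchange at hand. No step beyond the scatter is expected in this assay and the estimated change is a 1.2-fold lower number from compound 3 to compound 4 (0.07 log units; within the scatter) on this evidence. Compound 4 is estimated at 4500 nM with an expected range from 2200 nM to 9000 nM in this read-out.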

Compound 4, half-maximal inhibitory concentration: 1000 nM
For compound 4 the middle estimate is 4.5-fold (0.65 log units) above the measured one; measured number below the stated range.
By their numbers in this assay, from the lowest: compound 4; then compounds 1, 2 and 3 (each within the scatter of the next).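

Until now this place on the benzyl group had looked indifferent, with the three earlier compounds all within the scatter of one another, but in this assay the 4-chlorophenyl group stands apart, as chloro in place of dimethylamino gives a 5.3-fold lower number from compound 3 to compound 4 (0.72 log units; beyond the scatter) and the step lies beyond the scatter. Chloro in place of methoxy on the same aromatic carbon points the same way, with a 4.0-fold lower number from compound 1 to compound 4 (0.60 log units; beyond the scatter) also beyond the scatter, so both exchanges at this carbon lower the number. Compound 2 carries chloro at this place too, yet hydrogen in place of its second chloro gives a 5.0-fold lower number from compound 2 to compound 4 (0.70 log units; beyond the scatter) as well, so chloro para to a large group does not by itself set a compound apart: the lower number belongs to the 4-chlorophenyl group as a whole.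

The data shown offer no measurement that accounts for these steps. As far as these compounds go, whether fluoro, bromo, methyl or plain hydrogen at this place would keep the lower number remains open, and so does whether the result is specific to chloro.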